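Dimethylamino for chloro on the fused core

The source may report more compounds than this note shows. Statements on the series, on what has been measured and on what is new or still open speak of the compounds shown alone.

Measured so far:
compound 1 `CN(C)c1ccc(C#Cc2c(F)cccc2F)cn1` — 83.6%
compound 2 `Fc1cccc(F)c1C#Cc1cnc(Cl)c2ccccc12` — 94%

In a functional assay on LS174T cells (Homo sapiens) for inhibition, with a stated time of 4 days, tested at 10 uM (on this read-out lower numbers stand for a weaker effect and higher numbers for a stronger effect at the one concentration tested), compound 2 gives 94%, the highest of the two numbers; the nearest is compound 1 with 83.6%, a gap beyond the scatter. Compound 3 `CN(C)c1ncc(C#Cc2c(F)cccc2F)c2ccccc12` differs from compound 2 by dimethylamino in place of chloro on an aromatic carbon. For the measured compounds named here, no measured pair isolates this change. Compound 1 also carries a dimethylamino group and sits at 83.6%, so a modest downward step is expected, a number 6 percentage points lower from compound 2 to compound 3 (within the scatter), likely near the edge of the scatter. Compound 3 is estimated at 88% in this assay, with a range from 70% to 97%.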

Compound 3, a percentage reported as inhibition, at one concentration (the size of the read-out at that concentration, not a potency): 97.6%
Compound 3: middle estimate off by 9.6 percentage points, on the low side, outside the stated range (above it).
By their numbers in this assay, from the lowest: compound 1; then compounds 2 and 3 (each within the scatter of the next).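

On the aromatic carbon next to the ring nitrogen of the fused core, dimethylamino in place of chloro gives a number 3.6 percentage points higher from compound 2 to compound 3 (within the scatter) in this assay, so this pair shows no separation between the two groups. The position thus accepts a group of 3 heavy atoms in place of a single chlorine without a change beyond the scatter at the one concentration tested. No evidence bears on why the two groups read alike.

As far as these compounds go, whether methylamino, morpholine or a plain hydrogen at this carbon would hold the read-out remains open. From the compounds shown here alone, because both values come from a single concentration, any potency difference between compound 2 and compound 3 also remains open.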